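The compounds below may be only part of what the source reports. "The series", "measured", "known", "first", "only" and "open" are said of these compounds alone.

Working notes on the series. Compound 1 `CCCOc1ccc(C(=O)/C=C/c2ccc(C(=O)Nc3cccc(-c4cc(C(=O)OC)no4)c3)cc2)cc1` carries a propoxy group on one aromatic ring, an enone bridge, and an amide-linked ester-bearing portion. Compound 3 `COC(=O)c1cc(-c2cccc(NC(=O)c3ccc(/C=C/C(=O)c4ccc(Cl)cc4)cc3)c2)on1` is its counterpart after one change, (chloro in place of propoxy on an aromatic carbon). Compound 2 `CCCOc1ccc(C(=O)/C=C/c2ccc(C(=O)O)cc2)cc1` is a smaller acid; how the core of compound 2 differs from the core of compound 1 is not broken down here. Compound 4 `O=C(O)c1ccc(/C=C/C(=O)c2ccc(Cl)cc2)cc1`, not yet measured, stands to compound 2 as compound 3 stands to compound 1, the same change at the same place: chloro in place of propoxy on an aromatic carbon.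

In an ADME assay on Vero cells (Chlorocebus sabaeus) for cytotoxicity, read by MTT assay, with a stated time of 72 h (a lower number here means that less compound is tolerated, a higher number that more compound is tolerated), compound 1 gives > 40 ug/mL, which is a limit of the assay and not a number. Compound 3 gives > 50 ug/mL in this assay, also a limit. Compound 2 gives < 10 ug/mL in this assay, again a limit. The measured step that the two limits leave unreadable from compound 1 to compound 3 cannot be sized, since the limit of > 40 ug/mL in this assay, at which 1 of the 3 values shown sits, and the limit of > 50 ug/mL in this assay, at which 1 of the 3 values shown sits, both sit where no number is read.

Going by the values given here, for compound 4 the only anchor is compound 2 sitting at the limit of < 10 ug/mL in this assay, at which 1 of the 3 values shown sits, in this assay. The step from compound 1 to compound 3 gives no readable size to carry over, so the expectation for compound 4 leans on the low limit of compound 2 alone. Compound 4 is expected to give about 7 ug/mL in this assay, between 3 ug/mL and 15 ug/mL. The estimated step that the limit leaves unreadable from compound 2 to compound 4 is therefore expected to be small, and a further limit rather than a number is quite possible for compound 4.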

Compound 4, half-maximal cytotoxic concentration: < 10 ug/mL
Compound 4 ended at the assay's limit; the forecaster's own chance of this, stated with the estimate: 55%; the middle value does not contradict the limit.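

In this assay compound 4 gives < 10 ug/mL, which is a limit of the assay and not a number. Compound 2 stands at the same limit, so no step can be read from compound 2 to compound 4: the limit of < 10 ug/mL in this assay, at which 2 of the 4 values shown sit.

The compounds shown leave open how large the effect of chloro in place of propoxy is on either core, as all four values are limits.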